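Chloro in place of methoxy, seen twice in one series

A few compounds are considered here, and "the series" means these few. Any claim that something is new, unique, unknown or untested is made for them only; others in the source may bear on it.

The study follows a small set of hydrazone compounds tested in a functional assay on PC-3 cells (Homo sapiens) for cytotoxicity; on this read-out higher numbers stand for weaker inhibition and lower numbers for stronger inhibition. Compound 1 `COc1ccc(Cn2cc(/C=N\NC(=O)c3c[nH]c4ccc(Br)cc34)c3cc(OC)ccc32)cc1` gives 28000 nM in this assay. Compound 2 `COc1ccc2c(c1)c(/C=N\NC(=O)c1c[nH]c3ccc(Br)cc13)cn2Cc1ccc(Cl)cc1` gives 15900 nM. The change between them, (chloro in place of methoxy on an aromatic carbon), produced a 1.8-fold lower number from compound 1 to compound 2 (0.25 log units; within the scatter). Compound 3 `COc1ccc(Cn2cc(/C=N\NC(=O)c3c[nH]c4ccc(Br)cc34)c3ccc(F)cc32)cc1` gives 21800 nM, a number that lies within the scatter of both compound 1 and compound 2. The difference between the core of compound 1 and the core of compound 3 is not broken down here.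

Compound 4 `O=C(N/N=C\c1cn(Cc2ccc(Cl)cc2)c2cc(F)ccc12)c1c[nH]c2ccc(Br)cc12` has not yet been measured. Going by the values given here, it differs from compound 3 by chloro in place of methoxy on an aromatic carbon, which is the same change as the one made from compound 1 to compound 2, set on the same place, so the two changes are the same kind of change. Since the earlier step from compound 1 to compound 2 stayed within the scatter, compound 4 is expected to move from compound 3 by a comparable small step, a 1.7-fold lower number from compound 3 to compound 4 (0.22 log units; within the scatter), because the only comparable case is a 1.8-fold lower number from compound 1 to compound 2 (0.25 log units; within the scatter). On that basis, compound 4 is estimated to give about 13000 nM in this assay, with a likely span from 6000 nM to 30000 nM. With just one prior example of the change, the expectation rests on a narrow base, and the measured number will show whether the step holds.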

Compound 4, half-maximal inhibitory concentration: 12400 nM
Compound 4: the middle estimate sits 1.0-fold (0.02 log units) above what was measured; low and high end bracket the measured number.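

On the core of compound 3, 4-chlorobenzyl in place of 4-methoxybenzyl gave in this assay a 1.8-fold lower number from compound 3 to compound 4 (0.25 log units; within the scatter), and set beside the earlier case, the change reads the same on both cores: the same change on two cores in this assay, a 1.8-fold lower number (0.25 log units; within the scatter) from compound 1 to compound 2 and a 1.8-fold lower number (0.25 log units; within the scatter) from compound 3 to compound 4, 1.0-fold (0.00 log units) apart, within the scatter of two such steps. Going by these compounds alone, in these two pairs, then, the step carried from one core to the other with no difference between the steps that rises above the scatter. Yet each step on its own lies within the scatter, so the pairs do not establish that chloro and methoxy differ at all in this read-out, and two cores say nothing about how the change would behave on a third core or in another kind of assay.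

The compounds shown hold this place on the benzyl group with methoxy or chloro alone, which leaves open how an amine, a carboxylic acid or a longer chain there would read in this assay. As far as these compounds go, the bromo group and the hydrazone link are the same in all four compounds, so whether replacing the bromo group with a nitrile, or the hydrazone link with a plain amide, would shift the numbers also stays open.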